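Sulfonyl for sulfanyl on the enone chain: compound 3 to 4

A few compounds are considered here, and "the series" means these few. Any claim that something is new, unique, unknown or untested is made for them only; others in the source may bear on it.

Compound 3 `O=C(/C(=C\c1c(O)cc(O)cc1O)SCc1ccc(Cl)cc1)c1ccc(Cl)cc1` gives in a functional assay on DU-145 cells (Homo sapiens) for inhibition, read by trypan blue exclusion, with a stated time of 96 h (on this read-out lower numbers stand for stronger inhibition of growth and higher numbers for weaker inhibition of growth), only a limit, > 100000 nM, the weakest read-out in the set (the limit of > 100000 nM in this assay, at which 1 of the 3 values shown sits). Compound 1 `O=C(/C(=C\c1c(O)cc(O)cc1O)SCc1ccc(Cl)cc1Cl)c1ccc(Cl)cc1` gives 25000 nM and compound 2 `O=C(/C(=C\c1c(O)cc(O)cc1O)Sc1ccc(Br)cc1)c1ccc(Cl)cc1` gives 50000 nM in this assay. Compound 4 `O=C(/C(=C\c1c(O)cc(O)cc1O)S(=O)(=O)c1ccc(Br)cc1)c1ccc(Cl)cc1` differs from compound 3 by (4-bromophenyl)sulfonyl in place of (4-chlorobenzyl)sulfanyl on a double-bonded chain carbon bound to a carbonyl carbon and a double-bonded chain carbon.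

For the measured compounds named here, two measured steps touch on this change. The step of an at least 2.0-fold higher number from compound 2 to compound 3 (0.30 log units; that floor lies within the scatter) runs in the opposite direction to the aryl part of the change now considered. Undoing that aryl part would point back toward compound 2. The step of an at least 4.0-fold higher number from compound 1 to compound 3 (0.60 log units; beyond the scatter) shows that removing a chloro from the benzyl ring weakened compound 3. Nothing measured covers sulfonyl in place of sulfanyl on the chain carbon, so that part of the change is unanchored. The expectation for compound 4 is therefore a return to the region of compound 2, with an at least 2.0-fold lower number from compound 3 to compound 4 (0.30 log units; that floor lies within the scatter) expected, and an estimated value of 50000 nM, between 15000 nM and 200000 nM.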

Compound 4, concentration for 50% growth inhibition: > 100000 nM
Compound 4 gave a limit, no number; the forecaster's own chance of this, stated with the estimate: 35%; middle value at least 2.0-fold (0.30 log units) from the limit.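

In this assay compound 4 gives only a limit, > 100000 nM, and the step from compound 3 cannot be read, both ends being limits: the limit of > 100000 nM in this assay, at which 2 of the 4 values shown sit.

With the 4-bromophenyl group kept on the sulfur, sulfonyl in place of sulfanyl gives an at least 2.0-fold higher number from compound 2 to compound 4 (0.30 log units; that floor lies within the scatter), so this first reading of the sulfur change shows no loss beyond the scatter. Against the 2,4-dichlorobenzyl sulfanyl group, (4-bromophenyl)sulfonyl on this chain carbon gives an at least 4.0-fold higher number from compound 1 to compound 4 (0.60 log units; beyond the scatter), so it does not hold the level of compound 1.

Going by these compounds, how much the sulfonyl itself costs stays open while compound 4 has no number. Also open, on these data alone, is whether a sulfonyl carrying 2,4-dichlorobenzyl, or an amine in place of the sulfur-linked group on this chain carbon, would give a number inside the range of the assay.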